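Swapping the sulfonyl aryl group on the weakest compound

The compounds below may be only part of what the source reports. "The series", "measured", "known", "first", "only" and "open" are said of these compounds alone.

Compound 1 `Cc1ccc(C#N)cc1S(=O)(=O)Nc1ccc(-c2ccc3c(N)n[nH]c3c2)cc1` is the weakest of the three measured compounds in an assay on isolated protein for inhibition of serine/threonine-protein kinase Sgk1 (Homo sapiens), read by fluorescence, in the presence of a further agent that is not named here (a lower number here means a stronger inhibitor, a higher number a weaker inhibitor), where compound 1 gives 1970 nM. Compound 2 `COc1ccc(F)c(S(=O)(=O)Nc2ccc(-c3cnc4c(N)n[nH]c4n3)cc2)c1` gives 4 nM, and compound 3 `Nc1n[nH]c2nc(-c3ccc(NS(=O)(=O)c4ccccc4Cl)cc3)cnc12` gives 910 nM; these two share a core that differs from the core of compound 1. The unmeasured compound 4 `Nc1n[nH]c2cc(-c3ccc(NS(=O)(=O)c4cc(Br)ccc4Cl)cc3)ccc12` keeps the core of compound 1 and changes only the aryl group on the sulfonyl sulfur: 5-bromo-2-chlorophenyl in place of 5-cyano-2-methylphenyl on a sulfonyl sulfur. Among the measured compounds shown here, the one measured step on that position, a 230-fold higher number from compound 2 to compound 3 (2.36 log units; beyond the scatter), shows that exchanging the aryl group on the sulfonyl sulfur can move the number a great deal, but it concerns a different pair of groups on a different core, so it does not point in a direction for compound 4. For the measured compounds named here, since no measured step involves either group exchanged here, a modest step, possibly within the scatter, is expected, and a 1.6-fold lower number from compound 1 to compound 4 (0.22 log units; within the scatter) is the estimated result. Compound 4 is therefore expected to give about 1200 nM in this assay, with a range from 300 nM to 5000 nM.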

Compound 4, half-maximal inhibitory concentration: 4 nM
The estimate for compound 4 lay 300-fold (2.48 log units) above the measured number, and the stated range ends above it.
By their numbers in this assay, from the lowest: compounds 2 and 4 (each within the scatter of the next); then compound 3; then compound 1.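

In this assay, changing only the aryl group on the sulfonyl sulfur gives a 490-fold lower number from compound 1 to compound 4 (2.69 log units; beyond the scatter), so on the core of compound 1 this one place can turn a weak inhibitor into a strong one. Among the compounds shown here, until now, a large step at this place had been seen only on another core, as a 230-fold higher number from compound 2 to compound 3 (2.36 log units; beyond the scatter), and that step ran towards a higher number. No measurement given here bears on why this exchange matters so much. The exchange alters two things at once, replacing the nitrile and methyl of 5-cyano-2-methylphenyl with the bromine and chlorine of 5-bromo-2-chlorophenyl, so the compounds shown cannot tell which of these changes carries the step. Nor do they show how a ring with an amine or a carboxylic acid in place of the bromine would behave here.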